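The source may report more compounds than this note shows. Statements on the series, on what has been measured and on what is new or still open speak of the compounds shown alone.

Of the compounds shown here, three have been read in a physicochemical assay for solubility, read by HPLC, using the shake flask method, measured as kinetic solubility, with a stated time of 20 h, at pH 6.5, tested at 200 uM; on this read-out higher numbers stand for higher solubility and lower numbers for lower solubility. Compound 1 `C[C@@H](CO)NS(=O)(=O)c1cccc(-c2ccc3nccc(-c4ccncc4)c3n2)c1` gives 50000 nM. Compound 2 `NS(=O)(=O)c1cccc(-c2ccc3nccc(-c4cccnc4)c3n2)c1` returns only a limit, < 5000 nM. Compound 3 `O=S(=O)(c1cccc(Nc2ccc3nccc(-c4ccncc4)c3n2)c1)N1CCCC1` also returns only a limit, < 5000 nM. Compound 3 thus stands at the limit of < 5000 nM in this assay, at which 2 of the 3 values shown sit, and no number is available for it.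

Compound 4 `O=S(=O)(NCc1ccccc1)c1cccc(Nc2ccc3nccc(-c4ccncc4)c3n2)c1` has not yet been measured. It carries benzylamino in place of pyrrolidin-1-yl on a sulfonyl sulfur.

Among the compounds with values here, no measured pair isolates this change, so there is no direct precedent for the size or direction of the step in this assay. No step beyond the usual scatter is expected, and the most likely outcome is another limit rather than a number. This expectation rests on compound 3, itself a limit at < 5000 nM. The expected step is a step that the limit leaves unreadable from compound 3 to compound 4. For compound 4 the estimated value is 3000 nM, with an expected range from 1000 nM to 8000 nM.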

Compound 4, solubility: < 5000 nM
Compound 4: a limit, no number; the forecaster's own chance of this, stated with the estimate: 80%; the middle value is on the limit's open side.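

No step can be read between compound 3 and compound 4 in this assay: both values are limits, not numbers. The compounds shown leave open what number either compound would give, and whether benzylamino in place of pyrrolidin-1-yl on a sulfonyl sulfur shifts the read-out at all.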